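Isobutyl for 1-methylbutyl on the ring nitrogen

A few compounds are considered here, and "the series" means these few. Any claim that something is new, unique, unknown or untested is made for them only; others in the source may bear on it.

Two compounds have numbers in a functional assay for antagonist activity at corticotropin-releasing factor receptor 1 (Rattus norvegicus) (a higher number here means a weaker inhibitor, a lower number a stronger inhibitor), so far. Compound 1 `CC[C@H](COC)n1c(=O)c(C)nc2c(-c3ccc(Cl)cc3Cl)ncnc21` gives 97 nM in this assay, and compound 2 `CCCC(C)n1c(=O)c(C)nc2c(-c3ccc(Cl)cc3Cl)ccnc21` gives 62 nM. The number of compound 2 is the lower of the two, but the gap to compound 1 lies within the scatter, so no order between them is claimed. Compound 3 `Cc1nc2c(-c3ccc(Cl)cc3Cl)ccnc2n(CC(C)C)c1=O` differs from compound 2 by isobutyl in place of 1-methylbutyl on an aromatic nitrogen. Within the data shown here, no measured pair mirrors this change. A modest loss is expected from compound 2 to compound 3 in this assay, a 2.4-fold higher number from compound 2 to compound 3 (0.38 log units; beyond the scatter), somewhat beyond the scatter. Compound 3 is estimated at 150 nM in this assay, with a range of 50 nM to 500 nM.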

Compound 3, half-maximal inhibitory concentration: 3500 nM
Compound 3: the middle estimate sits 23-fold (1.37 log units) below what was measured; the measured number lies above the stated range.
By their numbers in this assay, from the lowest: compounds 2 and 1 (each within the scatter of the next); then compound 3.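

On the aromatic nitrogen, the alkyl group matters far more in this assay than the first two compounds could show: isobutyl in place of 1-methylbutyl gives a 56-fold higher number from compound 2 to compound 3 (1.75 log units; beyond the scatter). Both groups are all carbon, with no ring and no hydrogen-bond donors or acceptors, so this position responds strongly to a change confined to the alkyl group. Nothing measured on these compounds accounts for the step.

Open, on these data alone, is whether a 1-ethylpropyl group or a longer straight chain would fare like 1-methylbutyl or like isobutyl. Also open, as far as these compounds go, is how an ether-bearing chain behaves on the core of compound 2.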